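The compounds below may be only part of what the source reports. "The series", "measured", "known", "first", "only" and "open" are said of these compounds alone.

Compound 1, `CCOC(=O)c1cc(/C=C/c2c(Cl)cncc2Cl)on1`, was examined in an ADME assay on Vero cells (Chlorocebus sabaeus) for cytotoxicity, with a stated time of 72 h; on this read-out lower numbers stand for stronger inhibition and higher numbers for weaker inhibition. In this assay compound 1 reaches only the limit of the measurement, > 128000 nM, which is a bound rather than a number. The partner compound 2, `CCOC(=O)c1cc(/C=C/c2cccc(-c3ccccn3)c2)on1`, gives 113000 nM in this assay, a value that falls in the same weak region. Compound 3, `CCCCCCCCOC(=O)c1cc(/C=C/c2c(Cl)cncc2Cl)on1`, has not yet been measured in this assay and differs from compound 1 in a single place: hexyl in place of hydrogen on a saturated chain carbon, two bonds along the chain from an oxygen next to a carbonyl group. Within the data shown here, no measured pair in this set shows what such a chain lengthening does to cell toxicity, so any expectation rests on compound 1 alone, whose weak activity is fixed by the limit of > 128000 nM in this assay, at which 1 of the 2 values shown sits. The step from compound 1 to compound 3 is expected to be an at least 2.1-fold lower number from compound 1 to compound 3 (0.32 log units; beyond the scatter), a modest shift toward stronger toxicity, yet small enough that it may not exceed the usual scatter. Compound 3 is therefore estimated at 60000 nM in this assay, with a plausible range from 15000 nM to 150000 nM, and a fair chance that only a limit is again reported.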

Compound 3, half-maximal inhibitory concentration: > 128000 nM
Compound 3 ended at the assay's limit; the forecaster's own chance of this, stated with the estimate: 40%; middle value at least 2.1-fold (0.32 log units) away from the limit.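

Compound 1 and compound 3 both stop at the limit of the measurement in this assay, which is a bound rather than a number, so no step between them can be read: the limit of > 128000 nM in this assay, at which 2 of the 3 values shown sit.

The compounds shown leave open whether hexyl in place of hydrogen at this place shifts the result in this assay at all, and in which direction.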